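Nitrophenyl piperazines at the serotonin 6 receptor: benzyl variations

The compounds below may be only part of what the source reports. "The series", "measured", "known", "first", "only" and "open" are said of these compounds alone.

Measured so far:
- compound 1 `CN1CCN(c2ccc([N+](=O)[O-])c(NCc3ccc(F)cc3)c2)CC1`: 172 nM
- compound 2 `O=[N+]([O-])c1ccc(N2CCNCC2)cc1NCCOc1ccccc1`: 114 nM

In an assay on HEK293 cells for displacement of a labelled ligand from 5-hydroxytryptamine receptor 6 (Homo sapiens) (on this read-out higher numbers stand for weaker inhibition and lower numbers for stronger inhibition), compound 1 gives 172 nM, the higher of the two numbers, with compound 2 at 114 nM lying within the scatter of it. Compound 3 `CC(Nc1cc(N2CCN(C)CC2)ccc1[N+](=O)[O-])c1ccccc1` has not yet been measured. It differs from compound 1 by 1-phenylethyl in place of 4-fluorobenzyl on a nitrogen on an aromatic ring. For the measured compounds named here, no step between measured compounds bears on this change, so the expected step is small: the expected size of a 1.2-fold higher number from compound 1 to compound 3 (0.07 log units; within the scatter) is no larger than the scatter, in either direction. For compound 3 the estimate in this assay is 200 nM, within 70 nM to 600 nM.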

Compound 3, inhibition constant: 12 nM
Compound 3: middle estimate off by 17-fold (1.22 log units), on the high side, and the stated range ends above it.
By their numbers in this assay, from the lowest: compound 3; then compounds 2 and 1 (each within the scatter of the next).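

The change from 4-fluorobenzyl to 1-phenylethyl on a nitrogen on an aromatic ring is large in this assay: a 14-fold lower number from compound 1 to compound 3 (1.16 log units; beyond the scatter). Both groups have the same heavy-atom count and one six-membered aromatic ring of carbon only, so this position responds strongly even when those counts stay the same. Nothing available here explains the step.

Two things changed at once, the fluorine and the added methyl, and plain benzyl on the core of compound 1 would separate them. From the compounds shown here alone, whether the two mirror-image forms of 1-phenylethyl differ also remains open.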